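HeLa series: from compound 2 to compound 3

The compounds below may be only part of what the source reports. "The series", "measured", "known", "first", "only" and "open" are said of these compounds alone.

Measured in a functional assay on HeLa cells (Homo sapiens) for inhibition, read by MTT assay, with a stated time of 72 h; on this read-out higher numbers stand for weaker inhibition and lower numbers for stronger inhibition:
compound 1 `CN(C(=O)NC(=O)c1cccc(C(F)(F)F)c1)c1nc(C(F)(F)F)c(C(=O)N/N=C/c2ccc(C(F)(F)F)cc2)s1` gives 7.35 ug/mL;
compound 2 `CN(C(=O)NC(=O)c1ccccc1F)c1nc(C(F)(F)F)c(C(=O)N/N=C/c2cc(C(F)(F)F)cc(C(F)(F)F)c2)s1` gives 4.98 ug/mL.

Within the data shown here, compound 2 holds the lowest of the two numbers in this assay, with compound 1 nearest at a slightly higher number that stays within the scatter; on these two values no ordering of the pair can be stated. Compound 3 `CN(C(=O)NC(=O)c1ccc(Cl)cc1Cl)c1nc(C(F)(F)F)c(C(=O)N/N=C/c2cc(C(F)(F)F)cc(C(F)(F)F)c2)s1` is not yet measured. It differs from compound 2 in one place: 2,4-dichlorophenyl in place of 2-fluorophenyl on a carbonyl carbon. The carbonyl carbon that carries the ring keeps its amide-type nitrogen neighbour, so the change is confined to the aromatic ring on that carbonyl, 2,4-dichlorophenyl in place of 2-fluorophenyl.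

Among the measured compounds shown here, no pair of measured compounds in this set differs at this position alone, so there is no measured step on which to size the change. The working expectation is therefore a step from compound 2 to compound 3 of a 1.0-fold higher number from compound 2 to compound 3 (0.00 log units; within the scatter), which is to say none beyond the scatter in either direction. Compound 3 is accordingly estimated at 5 ug/mL in this assay, within a range from 2 ug/mL to 12 ug/mL.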

Compound 3, half-maximal inhibitory concentration: > 100 ug/mL
Compound 3 was reported as a limit; the forecaster's own chance of this, stated with the estimate: 5%; middle value at least 20-fold (1.30 log units) away from the limit.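

In this assay, the aromatic ring on the carbonyl carbon proves to be a position that can carry a large effect: 2,4-dichlorophenyl in place of 2-fluorophenyl, with the rest of the structure unchanged, gives an at least 20-fold higher number from compound 2 to compound 3 (1.30 log units; beyond the scatter). Among these compounds, the earlier pair could not show this, since compound 1 and compound 2 differ in more than one place and their values lie within the scatter of each other, so this is the first step read at this position alone. For compound 3 the reading of > 100 ug/mL is a limit of the assay and not a number, and it is the only such reading in the set: the limit of > 100 ug/mL in this assay, at which 1 of the 3 values shown sits.

The compounds shown leave open whether the step belongs to the chlorine pair as a whole or to one chlorine alone, and how far it extends past the limit. A phenyl ring with no substituent, a ring with a single chlorine, or one bearing a methoxy group or an amine would be needed to place 2-fluorophenyl and 2,4-dichlorophenyl on a wider scale at this position.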